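Removing the Amino Group from the Pyridine Ring

The source may hold more compounds than are shown below. What is called first, only, known or untested is meant among the compounds shown, and "the series" means these compounds.

Of the compounds shown here, three have been measured in an assay on cells for inhibition of MAP kinase-interacting serine/threonine-protein kinase 1 (Homo sapiens), read by mobility shift assay, with stated times of 10 min and 60 min, in the presence of a further agent that is not named here; on this read-out lower numbers stand for stronger inhibition and higher numbers for weaker inhibition. Compound 1 `NCCOc1cc(-c2cccnc2)ccc1C(N)=O` gives 820 nM, compound 2 `Cc1ncccc1-c1ccc(C(N)=O)cc1` gives 170000 nM, and compound 3 `NC(=O)c1ccc(-c2ccc(N)nc2)cc1` gives 34000 nM. Compound 3 thus holds the second highest number of the three, standing below compound 2 and well above compound 1, with both gaps beyond the usual scatter. The unmeasured compound 4 `NC(=O)c1ccc(-c2cccnc2)cc1` differs from compound 3 in one place: hydrogen in place of amino on an aromatic carbon. Among the measured compounds shown here, with no measured pair showing this exact change, the step is expected to be moderate and toward a lower number, since compound 1, which also carries an unsubstituted pyridine, gives 820 nM. Compound 4 is therefore estimated at 10000 nM, within 2000 nM to 50000 nM, a step of a 3.4-fold lower number from compound 3 to compound 4 (0.53 log units; beyond the scatter).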

Compound 4, half-maximal inhibitory concentration: 8800 nM
Compound 4: the middle estimate sits 1.1-fold (0.06 log units) above what was measured; low and high end bracket the measured number.
By their numbers in this assay, from the lowest: compound 1; then compound 4; then compound 3; then compound 2.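

In this assay, hydrogen in place of amino, on the carbon next to the ring nitrogen, gives a 3.9-fold lower number from compound 3 to compound 4 (0.59 log units; beyond the scatter), so the amino group there goes with a higher number. Hydrogen in place of methyl gives a 19-fold lower number from compound 2 to compound 4 (1.29 log units; beyond the scatter), also downward, while hydrogen in place of 2-aminoethoxy gives an 11-fold higher number from compound 1 to compound 4 (1.03 log units; beyond the scatter), the only one of these changes that runs upward. Nothing shown here gives a reason for these steps. Going by these compounds, it remains open whether a methoxy or dimethylamino group on that carbon would go with a higher number as well. On these data alone, it also remains open how a longer chain ending in an amine would compare with 2-aminoethoxy.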